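A methoxy change repeated on a second core

The compounds below may be only part of what the source reports. "The series", "measured", "known", "first", "only" and "open" are said of these compounds alone.

Compound 1 `C=C(Br)C(=O)Nc1cccc(-c2cn3nc(-c4ccccc4)sc3n2)c1` gives 900 nM in a functional assay on FM3A cells (Mus musculus) for inhibition, read by cell counting, with a stated time of 2 days; a higher number here means a weaker inhibitor, a lower number a stronger inhibitor.
Compound 2 `C=C(Br)C(=O)Nc1cccc(-c2cn3nc(-c4cccc(OC)c4)sc3n2)c1` gives 500 nM in this assay.
Compound 3 `Nc1cccc(-c2cn3c(-c4ccccc4)csc3n2)c1` gives 34000 nM in this assay.

Compound 1 and compound 2 share one core and differ only by methoxy in place of hydrogen on an aromatic carbon. The step between them, a 1.8-fold lower number from compound 1 to compound 2 (0.26 log units; within the scatter), is within the scatter. Compound 3 carries a different core; the difference between the two cores is not broken down here. Compound 3 gives the highest number of the three, beyond the scatter from both compound 1 and compound 2.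

Compound 4 `COc1ccc(-c2csc3nc(-c4cccc(N)c4)cn23)cc1` is not yet measured. It differs from compound 3 by methoxy in place of hydrogen on an aromatic carbon. This is the same kind of change as that from compound 1 to compound 2, but not the same: in compound 2 the methoxy sits meta to a large group, in compound 4 para to a large group. Because a 1.8-fold lower number from compound 1 to compound 2 (0.26 log units; within the scatter) stayed within the scatter, a step of similar small size is expected here as well: a 1.4-fold lower number from compound 3 to compound 4 (0.13 log units; within the scatter). Compound 4 is therefore estimated at 25000 nM in this assay, with a range from 8000 nM to 70000 nM.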

Compound 4, half-maximal inhibitory concentration: 11000 nM
Estimate against measurement, compound 4: 2.3-fold (0.36 log units) above; low and high end bracket the measured number.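

In this assay the methoxy change on the core of compound 3 gives a 3.1-fold lower number from compound 3 to compound 4 (0.49 log units; beyond the scatter) and so stands clear of the scatter, which the step on the core of compound 1 does not. Even so, the two steps cannot be told apart from each other: the same change on two cores in this assay, a 1.8-fold lower number (0.26 log units; within the scatter) from compound 1 to compound 2 and a 3.1-fold lower number (0.49 log units; beyond the scatter) from compound 3 to compound 4, 1.7-fold (0.23 log units) apart, within the scatter of two such steps. Within the data shown here, this shows that the size of the change carried over between these two cores as far as the assay can resolve, but it does not show a general rule, since it rests on only two pairs, the methoxy does not occupy the same place in both, and the pairs also differ in the group on their other aromatic ring.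

The compounds shown leave open whether an ethoxy group, a fluorine or a hydroxyl on the same ring would give a step of similar size. They also leave open how a methoxy at another place on that ring would compare with the one para to a large group in compound 4.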